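The source may hold more compounds than are shown below. What is called first, only, known or untested is meant among the compounds shown, and "the series" means these compounds.

Measured so far:
compound 1 `c1ccc(CSc2nnc(-c3ccncc3)n2-c2ccccc2)cc1`, 12900 nM
compound 2 `O=C(CSc1nnc(-c2ccncc2)n1-c1ccccc1)N/N=C/c1ccccc1`, 18600 nM

In a functional assay on HepG2 cells (Homo sapiens) for inhibition, read by MTT assay, with a stated time of 48 h (on this read-out higher numbers stand for weaker inhibition and lower numbers for stronger inhibition), compound 2 gives 18600 nM, the highest of the two numbers recorded. Its nearest neighbour is compound 1, which in this assay gives 12900 nM; the gap between the two lies within the usual scatter of repeated measurements, so no order between them can be claimed, and the two compounds have not been compared as a single-point step.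

Compound 3 `O=C(CSc1nnc(-c2ccncc2)n1-c1ccccc1)N/N=C/c1cc(Br)ccc1O` has not yet been measured. It differs from compound 2 in one place: 5-bromo-2-hydroxyphenyl in place of phenyl on a carbon with a double bond to nitrogen. Going by the values given here, no measured pair shows how such a change plays out, so the expectation rests on compound 2 alone. A modest fall in the number in this assay is expected, of a size not far beyond the scatter, and the estimated step from compound 2 to compound 3 is a 2.1-fold lower number from compound 2 to compound 3 (0.32 log units; beyond the scatter). For compound 3 the expected value is 9000 nM, with a range from 3000 nM to 30000 nM.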

Compound 3, half-maximal inhibitory concentration: 4390 nM
Compound 3: middle estimate off by 2.1-fold (0.31 log units), on the high side; the measured number falls inside the stated range.
By their numbers in this assay, from the lowest: compound 3; then compounds 1 and 2 (each within the scatter of the next).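

In this assay, going by these compounds alone, putting 5-bromo-2-hydroxyphenyl in place of phenyl on a carbon with a double bond to nitrogen gives a 4.2-fold lower number from compound 2 to compound 3 (0.63 log units; beyond the scatter) and thus shows that the number responds to a change at this place, which no earlier pair could show. The step is modest but beyond the scatter, and it comes with a change that keeps the six-membered aromatic ring of carbon only while adding a bromine and an oxygen, with one hydrogen-bond donor and one hydrogen-bond acceptor where phenyl had none. These additions arrive together, so the step belongs to the whole 5-bromo-2-hydroxyphenyl group and cannot be divided among its parts, and no measurement at hand explains it. The compounds shown leave open whether the bromine or the hydroxy group alone would give a step of this size, and whether either would do so at another place on the ring. They also do not tell how an amine or a carboxylic acid in place of the hydroxy group, or a chlorine in place of the bromine, would behave in this series.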